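Solubility notes on an amide side-chain exchange

The compounds below may be only part of what the source reports. "The series", "measured", "known", "first", "only" and "open" are said of these compounds alone.

compound 1 `CN1CCC(C(=O)Nc2n[nH]c3c2CN(C(=O)C(C)(C)C)C3(C)C)CC1` gives > 225000 nM
compound 2 `CN1CCC(C(=O)N2Cc3c(NC(=O)c4cccc(F)c4)n[nH]c3C2(C)C)CC1` gives > 225000 nM

Both readings come from a physicochemical assay for solubility, at pH 7; on this read-out higher numbers stand for higher solubility and lower numbers for lower solubility. For compound 1 the value is a limit of the assay, not a number. For compound 2 the value is likewise a limit. Within the data shown here, compound 1 therefore stands at the limit of > 225000 nM in this assay, at which 2 of the 2 values shown sit, with no measured step to place it against. Compound 3 `CN(C)CC(=O)Nc1n[nH]c2c1CN(C(=O)C(C)(C)C)C2(C)C` differs from compound 1 by (dimethylamino)methyl in place of 1-methylpiperidin-4-yl on a carbonyl carbon. Among the measured compounds shown here, no step between measured compounds exists here; the expected step from compound 1 is a number no higher from compound 1 to compound 3 (the limit leaves the size open), none beyond the scatter. Compound 3 is thus expected to read about 225000 nM, in the range 110000 nM to 450000 nM, most likely again as a limit.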

Compound 3, solubility: > 225000 nM
Compound 3: no number, only a limit; the forecaster's own chance of this, stated with the estimate: 80%; the middle value lies on the limit itself.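

No step can be read from compound 1 to compound 3 in this assay, as each reading is only a limit: the limit of > 225000 nM in this assay, at which 3 of the 3 values shown sit.

Where these compounds truly lie relative to that limit, and what exchanging 1-methylpiperidin-4-yl for (dimethylamino)methyl does to the read-out, stays open.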